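A few compounds are considered here, and "the series" means these few. Any claim that something is new, unique, unknown or untested is made for them only; others in the source may bear on it.

Three analogues share the core of compound 1 `Cc1cc(Nc2nn(Cc3ccc(S(C)(=O)=O)cc3)c(=O)c3ccccc23)n[nH]1`. In a functional assay on COLO 205 cells (Homo sapiens) for cytotoxicity (a higher number here means a weaker inhibitor, a lower number a stronger inhibitor), compound 1 gives 4500 nM. Compound 2 `Cc1cc(Nc2nn(Cc3cc(F)ccc3F)c(=O)c3ccccc23)n[nH]1` gives 3800 nM in this assay, a number that lies within the usual scatter of that of compound 1, so the two cannot be told apart. For compound 3 `Cc1ccc(-n2nc(Nc3cc[nH]n3)c3ccccc3c2=O)cc1` the entry in this assay reads "not determined" (no result reported), so no result was reported. Compound 4 `CC(=O)Nc1ccc(Cn2nc(Nc3cc(C)[nH]n3)c3ccccc3c2=O)cc1` differs from compound 1 by a single change: acetamido in place of methylsulfonyl on an aromatic carbon. For the measured compounds named here, no measured pair shows this change, so its effect on potency is unknown from these data. The step of a 1.1-fold lower number from compound 1 to compound 4 (0.05 log units; within the scatter) in this assay is expected to stay within the scatter, in neither direction beyond it. Compound 4 is therefore estimated at 4000 nM in this assay, with a range from 1500 nM to 12000 nM.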

Compound 4, half-maximal inhibitory concentration: > 30000 nM
Compound 4 gave a limit, no number; the forecaster's own chance of this, stated with the estimate: 10%; at least 7.5-fold (0.87 log units) between middle value and limit.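

In this assay compound 4 reads > 30000 nM, which is a limit of the assay and not a number. Acetamido in place of methylsulfonyl on this aromatic carbon, para to a large group, gives an at least 6.6-fold higher number from compound 1 to compound 4 (0.82 log units; beyond the scatter), so this position does not accept every group of this size alike. The true size of the step stays unknown, as it rests on a limit: the limit of > 30000 nM in this assay, at which 1 of the 4 values shown sits.

On these data alone, whether an amine or a carboxylic acid at this position would read closer to compound 1 or to compound 4 remains open.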